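A few compounds are considered here, and "the series" means these few. Any claim that something is new, unique, unknown or untested is made for them only; others in the source may bear on it.

Measured so far in a functional assay on PC-3 cells (Homo sapiens) for inhibition; on this read-out lower numbers stand for stronger inhibition and higher numbers for weaker inhibition:
compound 1 `Cc1c(C(=O)N/N=C\c2cc(F)ccc2O)oc2cccc(O)c12` gives 3170 nM
compound 2 `COc1cccc(/C=N\NC(=O)c2oc3cccc(O)c3c2C)c1` gives only a limit, >= 40000 nM
compound 3 `Cc1c(C(=O)N/N=C\c2ccccc2F)oc2cccc(O)c12` gives only a limit, >= 40000 nM

Going by the values given here, compound 1 thus holds the only definite number among the three; the other two sit at the limit of >= 40000 nM in this assay, at which 2 of the 3 values shown sit. Compound 4 `Cc1c(C(=O)N/N=C\c2ccc(F)cc2)oc2cccc(O)c12` differs from compound 1 by 4-fluorophenyl in place of 5-fluoro-2-hydroxyphenyl on a carbon with a double bond to nitrogen. Among the compounds with values here, two measured steps bear on this change, and each replaced the same 5-fluoro-2-hydroxyphenyl group: an at least 12-fold higher number from compound 1 to compound 2 (1.10 log units; beyond the scatter) and an at least 12-fold higher number from compound 1 to compound 3 (1.10 log units; beyond the scatter). In both cases the number rose past the limit. Compound 4 also lacks the 5-fluoro-2-hydroxyphenyl group, so a large rise is expected, a 13-fold higher number from compound 1 to compound 4 (1.10 log units; beyond the scatter), quite possibly ending at the limit once more. Compound 4 is therefore estimated at 40000 nM, in a range from 10000 nM to 120000 nM.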

Compound 4, half-maximal inhibitory concentration: >= 40000 nM
Compound 4 ended at the assay's limit (the forecaster's own chance of this, stated with the estimate: 65%); the middle value sits exactly at the limit.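

Replacing 5-fluoro-2-hydroxyphenyl with 4-fluorophenyl gives an at least 12-fold higher number from compound 1 to compound 4 (1.10 log units; beyond the scatter), and the result for compound 4 is only a limit of the assay. Compound 3 and compound 4 both carry a fluorophenyl group without the hydroxy group, and neither gives a definite number, so a ring fluorine alone does not preserve a measurable value in these two compounds. The steps among compound 2, compound 3 and compound 4 cannot be read, because each of these compounds gives only a limit: the limit of >= 40000 nM in this assay, at which 3 of the 4 values shown sit.

Still open, from the compounds shown here alone, is whether 2-hydroxyphenyl, without any fluorine, would give a definite number. Going by these compounds, it is also open whether an amine in place of the hydroxy group would do so.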